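A few compounds are considered here, and "the series" means these few. Any claim that something is new, unique, unknown or untested is made for them only; others in the source may bear on it.

Values so far in an ADME assay on Raji cells (Homo sapiens) for cytotoxicity, with a stated time of 72 h (a lower number here means that less compound is needed, a higher number that more compound is needed for the effect), for the series

- compound 1 `Cc1cc(NC(=O)Nc2ccc(Cl)c(Cl)c2)c2ccccc2n1` gives 10000 nM as a number
- compound 2 `COc1ccc(NC(=O)Nc2cc(C)nc3ccccc23)cc1OC` gives > 25000 nM as a limit

Compound 2 reads > 25000 nM as a limit of the assay and not as a number. From the compounds shown here alone, its true position therefore remains open.

Compound 3 `COc1ccc(NC(=O)Nc2cc(C)nc3ccccc23)cc1Cl` has chloro in place of methoxy on an aromatic carbon of compound 2 chloro in place of methoxy on an aromatic carbon and this carbon is ortho to a methoxy group and meta to a large group. Going by the values given here, no step between measured compounds is available, so the size of this change has no direct precedent. Compound 1 also carries chloro and no methoxy, and with compound 1 at 10000 nM in this assay a modest move towards less compound needed is expected. The expected change an at least 1.6-fold lower number from compound 2 to compound 3 (0.22 log units; that floor lies within the scatter) is therefore small and points to a lower number. For compound 3 the estimated value is 15000 nM with an expected range from 7000 nM to 30000 nM in this assay and another report as a limit would not be a surprise.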

Compound 3, half-maximal effective concentration: > 25000 nM
Compound 3: no number, only a limit; the forecaster's own chance of this, stated with the estimate: 35%; at least 1.6-fold (0.22 log units) between middle value and limit.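

In this assay compound 3 reads > 25000 nM, which is a limit of the assay and not a number. Chloro in place of methoxy at this carbon, ortho to a methoxy group and meta to a large group, therefore does not bring the series back into the readable range, and the step between the two limits cannot be read, because the comparison runs into the ceiling of the assay: the limit of > 25000 nM in this assay, at which 2 of the 3 values shown sit. The one readable step is an at least 2.5-fold higher number from compound 1 to compound 3 (0.39 log units; beyond the scatter), with methoxy in place of chloro on an aromatic carbon, so chloro on this one carbon, with the methoxy group kept on the ring, does not restore the number seen for compound 1.

From the compounds shown here alone, whether chloro and methoxy differ at all at this carbon stays open, since neither compound 2 nor compound 3 has a true value in this assay. Also open, going by these compounds, is how the value would respond to an amine, a carboxylic acid or a longer alkoxy chain on this carbon, and whether any of these would give a readable number.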